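The compounds below may be only part of what the source reports. "The series", "measured", "known", "first", "only" and "open" are said of these compounds alone.

Measured compounds in an ADME assay on HepG2 cells (Homo sapiens) for cytotoxicity, read by MTT assay, with a stated time of 72 h; a lower number here means that less compound is tolerated, a higher number that more compound is tolerated:
- compound 1, `O=[N+]([O-])c1c(CS(=O)(=O)c2ccccc2)nc2c(-c3ccccc3)cc(Cl)cn12`: > 15600 nM
- compound 2, `O=[N+]([O-])c1c(CS(=O)(=O)c2ccccc2)nc2c(-c3ccccc3CO)cc(Cl)cn12`: 88000 nM
- compound 3, `O=[N+]([O-])c1c(CS(=O)(=O)c2ccccc2)nc2c(-c3cccc(F)c3)cc(Cl)cn12`: > 12500 nM

The three compounds share one core and differ only in the aryl group attached to it. Compound 1 stands at a limit of the measurement in this assay, so its value is not a number but the edge of what the assay could resolve. Compound 3 also stands at a limit there. Within the data shown here, compound 2 is the only one with a resolved number. Because of these limits, a step that the limit leaves unreadable from compound 1 to compound 2 cannot be read in size, nor can a step that the two limits leave unreadable from compound 1 to compound 3 or a step that the limit leaves unreadable from compound 2 to compound 3; the limit of > 12500 nM in this assay, at which 1 of the 3 values shown sits, and the limit of > 15600 nM in this assay, at which 1 of the 3 values shown sits, mark where two of the three values sit.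

Compound 4, `O=[N+]([O-])c1c(CS(=O)(=O)c2ccccc2)nc2c(-c3ccncc3)cc(Cl)cn12`, has not been measured. It differs from compound 1 in that (pyridin-4-yl in place of phenyl on an aromatic carbon), that is, pyridin-4-yl in place of phenyl on the same aromatic carbon. Among the measured compounds shown here, none of the measured steps gives a readable size for any change at this position, so no direction beyond the scatter can be derived. Compound 4 is therefore expected to remain weakly cytotoxic, with an estimate of 40000 nM and a range from 12000 nM to 130000 nM. The expected step is a step that the limit leaves unreadable from compound 1 to compound 4, with a real chance that the assay again reports only a limit.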

Compound 4, half-maximal cytotoxic concentration: > 50000 nM
Compound 4 gave a limit, no number; the forecaster's own chance of this, stated with the estimate: 55%; at least 1.2-fold (0.09 log units) between middle value and limit.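

In this assay compound 4 gives > 50000 nM, a limit and not a number. Among these compounds, no step from compound 1, compound 2 or compound 3 to compound 4 can be read in size. The compounds shown leave open whether pyridin-4-yl in place of phenyl changes the tolerated concentration, and in which direction.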